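A few compounds are considered here, and "the series" means these few. Any claim that something is new, unique, unknown or untested is made for them only; others in the source may bear on it.

Working notes on the series. The measurement in hand is an ADME assay on RAW264.7 cells (Mus musculus) for cytotoxicity, read by resazurin assay, with a stated time of 48 h; a higher number here means that more compound is tolerated, a lower number that less compound is tolerated. Compound 1, `CCn1cc2ccc(N/C(C)=C3\C(=O)C=C(C)OC3=O)cc2n1`, gives in this assay only a limit, > 100000 nM, which is the limit of > 100000 nM in this assay, at which 1 of the 2 values shown sits. Compound 2, `CC1=CC(=O)/C(=C(/C)Nc2ccc3c(Cl)n(C)nc3c2)C(=O)O1`, gives in this assay 6260 nM. Among the values shown this is the only number, so compound 2 has no measured neighbour against which its position could be set.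

Compound 3, `CCn1nc2cc(N/C(C)=C3\C(=O)C=C(C)OC3=O)ccc2c1Cl`, is not yet measured in this assay. It differs from compound 2 by methyl in place of hydrogen on a saturated chain carbon bound to an aromatic nitrogen, in words: methyl in place of hydrogen on a saturated chain carbon bound to an aromatic nitrogen. No step between measured compounds covers such a change, and the one number shown gives no direction to lean on. For a change of this size the expectation is a step from compound 2 to compound 3 of a 1.1-fold higher number from compound 2 to compound 3 (0.05 log units; within the scatter), which is no step beyond the scatter. Compound 3 is therefore estimated at 7000 nM in this assay, within a range from 2500 nM to 20000 nM.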

Compound 3, half-maximal cytotoxic concentration: 6250 nM
Compound 3: the middle estimate sits 1.1-fold (0.05 log units) above what was measured, within the range that was stated.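

In this assay, methyl in place of hydrogen on a saturated chain carbon bound to an aromatic nitrogen gives a 1.0-fold lower number from compound 2 to compound 3 (0.00 log units; within the scatter), so this methyl to ethyl difference does not separate the two compounds when the chloro group is present. Within the data shown here, with the ethyl group common to both compounds, chloro in place of hydrogen on an aromatic carbon gives an at least 16-fold lower number from compound 1 to compound 3 (1.20 log units; beyond the scatter), which is the first step beyond the scatter and shows that this position matters more here than the chain does. Compound 1 stands at a limit, so the size of that step is a bound and not a number: the limit of > 100000 nM in this assay, at which 1 of the 3 values shown sits.

Going by these compounds, it remains open whether bromo, fluoro or an amine on that aromatic carbon would give a similar step. On these data alone, it is also open whether a longer chain such as propyl, or a chain ending in a carboxylic acid, would still leave the number within the scatter.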